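Swapping the anilino substituent on a cinnamoyl thiazole

A few compounds are considered here, and "the series" means these few. Any claim that something is new, unique, unknown or untested is made for them only; others in the source may bear on it.

Compound 1 `Cc1nc(Nc2cccc(Cl)c2)sc1C(=O)/C=C/c1ccccc1` gives in a functional assay on NCI-H460 cells (Homo sapiens) for cytotoxicity, read by MTT assay (a lower number here means a stronger inhibitor, a higher number a weaker inhibitor), only a limit, > 25000 nM, so its position is not a number. Compound 2 `Cc1nc(Nc2cccc(Cl)c2)sc1C(=O)/C=C/c1ccc(Cl)cc1` likewise gives only a limit in this assay, > 25000 nM. The step from compound 1 to compound 2 is therefore a step that the two limits leave unreadable from compound 1 to compound 2. Compound 3 `Cc1ccccc1Nc1nc(C)c(C(=O)/C=C/c2ccccc2)s1` differs from compound 1 by 2-methylphenyl in place of 3-chlorophenyl on a nitrogen on an aromatic ring. Among the measured compounds shown here, no measured step reads on this change; the only evidence is the limit of > 25000 nM in this assay, at which 2 of the 2 values shown sit. Compound 3 is expected to remain at that limit because compound 1 sits at the limit of > 25000 nM in this assay, at which 2 of the 2 values shown sit. For compound 3 the estimate is 30000 nM, ranging from 5000 nM to 120000 nM. The expected step is a step that the limit leaves unreadable from compound 1 to compound 3.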

Compound 3, half-maximal inhibitory concentration: > 25000 nM
Compound 3 gave a limit, no number; the forecaster's own chance of this, stated with the estimate: 70%; the middle value lies beyond the limit too.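

Compound 3, like compound 1, gives only a limit in this assay, so the step between them cannot be read: the limit of > 25000 nM in this assay, at which 3 of the 3 values shown sit.

The compounds shown leave open whether any of these substituent changes shifts potency in this assay.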